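Hydroxamate side chain on the piperazine urea: shortening

A few compounds are considered here, and "the series" means these few. Any claim that something is new, unique, unknown or untested is made for them only; others in the source may bear on it.

Of the compounds shown here, three of the shared core have been measured in an assay on isolated protein for inhibition of E3 ubiquitin-protein ligase Mdm2 (Homo sapiens), read by fluorescence polarization, with a stated time of 30 min; on this read-out lower numbers stand for stronger inhibition and higher numbers for weaker inhibition. Compound 1 `CCOc1cc(C(C)(C)C)ccc1C1=NC(c2ccc(Cl)cc2)C(c2ccc(Cl)cc2)N1C(=O)N1CCN(CCCCCC(=O)NO)CC1` gives 170 nM, compound 2 `CCOc1cc(C(C)(C)C)ccc1C1=NC(c2ccc(Cl)cc2)C(c2ccc(Cl)cc2)N1C(=O)NCCCCCCC(=O)Nc1ccccc1N` gives 620 nM, and compound 3 `CCOc1cc(C(C)(C)C)ccc1C1=NC(c2ccc(Cl)cc2)C(c2ccc(Cl)cc2)N1C(=O)N1CCN(Cc2ccc(C(=O)NO)cc2)CC1` gives 260 nM. Compound 3 thus stands second highest of the three numbers; its nearest neighbour is compound 1, at a lower number but within the scatter, while compound 2 lies beyond the scatter at the higher end.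

Compound 4 `CCOc1cc(C(C)(C)C)ccc1C1=NC(c2ccc(Cl)cc2)C(c2ccc(Cl)cc2)N1C(=O)N1CCN(CCCCC(=O)NO)CC1` is not yet measured. It differs from compound 3 as follows: 3-(hydroxycarbamoyl)propyl in place of 4-(hydroxycarbamoyl)phenyl on a saturated chain carbon bound to an amine nitrogen in a ring. Within the data shown here, the only measured step that bears on this position is a 1.5-fold higher number from compound 1 to compound 3 (0.18 log units; within the scatter), which exchanged a chain-borne hydroxamate for an aromatic one and stayed within the scatter. Compound 4 carries a chain-borne hydroxamate again, one carbon shorter than that of compound 1, so the change is expected to read roughly as the reverse of that step, toward the number of compound 1, and no move beyond the scatter is expected in this assay; the expected step is a 1.3-fold lower number from compound 3 to compound 4 (0.11 log units; within the scatter). For compound 4 the estimate in this assay is 200 nM, with a range from 90 nM to 450 nM.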

Compound 4, inhibition constant: 170 nM
The estimate for compound 4 lay 1.2-fold (0.07 log units) above the measured number, and the stated range covers the measured number.
By their numbers in this assay, from the lowest: compounds 1, 4 and 3 (each within the scatter of the next); then compound 2.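

In this assay, 3-(hydroxycarbamoyl)propyl in place of 4-(hydroxycarbamoyl)phenyl gives a 1.5-fold lower number from compound 3 to compound 4 (0.18 log units; within the scatter) and so, like the earlier exchange of the aromatic hydroxamate for 4-(hydroxycarbamoyl)butyl, does not separate the open chain from the ring-bearing side chain. The new information is on chain length: removing one carbon from the chain of compound 1 gives no change at the digits printed from compound 1 to compound 4 (within the scatter) and so leaves 4-(hydroxycarbamoyl)butyl and 3-(hydroxycarbamoyl)propyl indistinguishable on this read-out. Across these three compounds, the side chain on the saturated carbon bound to the ring amine nitrogen can thus change in length or carry an aromatic ring with no step beyond the scatter, and nothing on hand gives a reason for this flat reading.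

Open, as far as these compounds go, is how far this holds, for a shorter chain such as 2-(hydroxycarbamoyl)ethyl or for a chain longer than 4-(hydroxycarbamoyl)butyl. Also open, from the compounds shown here alone, is whether a carboxylic acid or a primary amide at the chain end would read like the hydroxamate.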